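Aryl-piperazine variation in a T-type channel inhibition series

The source may hold more compounds than are shown below. What is called first, only, known or untested is meant among the compounds shown, and "the series" means these compounds.

Measured compounds:
compound 1 `CCCc1nc(-c2ccccc2)c(CNCCN2CCN(c3cccc(C(F)(F)F)c3)CC2)o1` — 56.3%
compound 2 `CCCc1nc(-c2ccccc2)c(CNCCN2CCN(c3ccccc3OC)CC2)o1` — 39.7%
compound 3 `CCCc1nc(-c2ccccc2)c(CNCCN2CCN(c3ccccc3Cl)CC2)o1` — 60.1%

In an assay on HEK293 cells for inhibition of Voltage-dependent T-type calcium channel subunit alpha-1G (Homo sapiens), read by fluorescence, tested at 10 uM (a lower number here means less inhibition, a higher number more inhibition at the concentration tested (going by the name of the read-out)), compound 3 gives the highest of the three numbers, though compound 1 sits within the scatter of it; only compound 2 lies clearly lower, by a number 20.4 percentage points higher from compound 2 to compound 3 (beyond the scatter). Compound 4 `CCCc1nc(-c2ccccc2)c(CNCCN2CCN(c3ccc(OC)cc3)CC2)o1` is the next step from compound 3: 4-methoxyphenyl in place of 2-chlorophenyl on an amine nitrogen in a ring. For the measured compounds named here, two measured steps bear on it. Replacing 3-(trifluoromethyl)phenyl with 2-methoxyphenyl gave a number 16.6 percentage points lower from compound 1 to compound 2 (beyond the scatter), and chloro in place of methoxy gave a number 20.4 percentage points higher from compound 2 to compound 3 (beyond the scatter), so a methoxy-bearing ring has so far meant the lower number. A modest drop is therefore expected for compound 4, a number 18.1 percentage points lower from compound 3 to compound 4 (beyond the scatter), giving an estimated 42% with a range from 25% to 60%.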

Compound 4, a percentage reported as inhibition, at one concentration (the size of the read-out at that concentration, not a potency): 51.5%
Beside the measured number, compound 4's estimate is 9.5 percentage points below it; measured number inside the range.
By their numbers in this assay, from the lowest: compound 2; then compounds 4, 1 and 3 (each within the scatter of the next).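

In this assay, 4-methoxyphenyl in place of 2-methoxyphenyl on the amine nitrogen in the ring gives a number 11.8 percentage points higher from compound 2 to compound 4 (beyond the scatter), so a methoxy-bearing ring does not by itself mean the lower number; where the methoxy sits on that ring also counts. Compound 4 is not separated from the other two aryl groups, with a number 8.6 percentage points lower from compound 3 to compound 4 (within the scatter) and a number 4.8 percentage points lower from compound 1 to compound 4 (within the scatter). Nothing measured here explains these steps.

From the compounds shown here alone, whether chloro or trifluoromethyl also depends on its place on the ring remains open. So does the outcome for an unsubstituted phenyl or for a ring carrying an amine.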